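Phenyl Replaces Ethyl on the Carbamate Chain Carbon

The compounds below may be only part of what the source reports. "The series", "measured", "known", "first", "only" and "open" are said of these compounds alone.

Values in an assay on H4 cells for inhibition of Fatty-acid amide hydrolase 1 (Homo sapiens) (on this read-out lower numbers stand for stronger inhibition and higher numbers for weaker inhibition), so far:
compound 1 `CCOC(=O)CC(CC)CCCCCn1c(C)nc(-c2ccccc2)c1-c1ccccc1` gives 9900 nM
compound 2 `Cc1nc(-c2ccccc2)c(-c2ccccc2)n1CCCCCCC(=O)N(C)C` gives 970 nM
compound 3 `CCC(CCCCCn1c(C)nc(-c2ccccc2)c1-c1ccccc1)NC(=O)Oc1ccccc1F` gives 30 nM

Compound 3 has the lowest number of the three, and the steps leading to it are large: a 10-fold lower number from compound 1 to compound 2 (1.01 log units; beyond the scatter) and a 330-fold lower number from compound 1 to compound 3 (2.52 log units; beyond the scatter). Compound 4 `Cc1nc(-c2ccccc2)c(-c2ccccc2)n1CCCCCC(NC(=O)Oc1ccccc1F)c1ccccc1` differs from compound 3 by phenyl in place of ethyl on a saturated chain carbon bound to an amide-type nitrogen and a saturated chain carbon. Among the measured compounds shown here, neither measured step changes the group on that carbon, so no step bears directly on this change; both only show that the tail region of this series shifts this assay strongly. The expected step of a 1.3-fold higher number from compound 3 to compound 4 (0.12 log units; within the scatter) is therefore small, within scatter, in no clear direction. Compound 4 is estimated at 40 nM, expected between 8 nM and 200 nM.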

Compound 4, half-maximal inhibitory concentration: 110 nM
Compound 4: middle estimate off by 2.8-fold (0.44 log units), on the low side, within the range that was stated.
By their numbers in this assay, from the lowest: compound 3; then compound 4; then compound 2; then compound 1.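

On the saturated chain carbon bound to an amide-type nitrogen and a saturated chain carbon, phenyl in place of ethyl gives a 3.7-fold higher number from compound 3 to compound 4 (0.56 log units; beyond the scatter) in this assay. This is the first change shown at this carbon, and it shows that the carbon can carry a six-membered aromatic ring at only a modest cost. Nothing measured here explains the rise in the number. Still open, as far as these compounds go, is how a methyl group or a longer chain on this carbon would compare with ethyl. A cyclohexyl ring there would show whether phenyl's aromatic ring matters or simply a ring of carbons.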